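The compounds below may be only part of what the source reports. "The series", "measured", "known", "first", "only" and "open" are said of these compounds alone.

Compound 1 `CCCC(C(C)C)n1ccc2cc(/C(C)=C/C(=O)Nc3ccccc3OCCCC(=O)O)ccc21`: 7.2 nM
Compound 2 `C/C(=C\C(=O)Nc1ccccc1OCCCC(=O)O)c1ccc2c(ccn2Cc2ccc(F)cc2)c1`: 97 nM
Compound 3 `CCCC(c1ccccc1)n1ccc2cc(/C(C)=C/C(=O)Nc3ccccc3OCCCC(=O)O)ccc21`: 9.1 nM

All three share one core and were tested in an assay on Prostate gland for inhibition of steroid 5-alpha-reductase (Rattus norvegicus); on this read-out higher numbers stand for weaker inhibition and lower numbers for stronger inhibition. Compound 3 gives 9.1 nM; its number sits close to that of compound 1 and well away from that of compound 2, with an 11-fold lower number from compound 2 to compound 3 (1.03 log units; beyond the scatter). Compound 4 `COc1ccc(C(c2ccccc2)n2ccc3cc(/C(C)=C/C(=O)Nc4ccccc4OCCCC(=O)O)ccc32)cc1` has not been measured yet. It differs from compound 3 in a single place: 4-methoxyphenyl in place of propyl on a saturated chain carbon bound to an aromatic carbon and an aromatic nitrogen. For the measured compounds named here, two measured steps bear on this. Putting phenyl in place of isopropyl gave a 1.3-fold higher number from compound 1 to compound 3 (0.10 log units; within the scatter), a move inside the usual scatter. Putting 1-phenylbutyl in place of 4-fluorobenzyl gave an 11-fold lower number from compound 2 to compound 3 (1.03 log units; beyond the scatter), a large gain. Compound 4 keeps a chain carbon carrying two groups on the aromatic nitrogen, as compound 3 does, and exchanges one group on it for an aromatic one, much as the step from compound 1 to compound 3 did. For compound 4 a modest step in this assay is therefore expected, a 1.6-fold higher number from compound 3 to compound 4 (0.22 log units; within the scatter). Compound 4 is estimated at 15 nM, with a range from 5 nM to 60 nM.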

Compound 4, half-maximal inhibitory concentration: 8.8 nM
Compound 4: the middle estimate sits 1.7-fold (0.23 log units) above what was measured; measured number inside the range.
By their numbers in this assay, from the lowest: compounds 1, 4 and 3 (each within the scatter of the next); then compound 2.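

In this assay, 4-methoxyphenyl in place of propyl on the saturated chain carbon bound to an aromatic carbon and an aromatic nitrogen gives a 1.0-fold lower number from compound 3 to compound 4 (0.01 log units; within the scatter), so the two compounds cannot be told apart on this read-out. Compounds 1, 2 and 3 could not show this: compounds 1 and 3 both keep propyl on this carbon, and compound 2 has a plain benzyl group, so compound 4 shows that this inhibition can hold without the propyl, even when a group of 8 heavy atoms with an aromatic ring and a hydrogen-bond acceptor replaces one of 3. Nothing available explains why the number holds.

Going by these compounds, it remains open how a plain phenyl would read in place of 4-methoxyphenyl, which would isolate the contribution of the methoxy group. Also open, on these data alone, is how this carbon would respond to a group carrying an amine or a carboxylic acid.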